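Swapping the aryl group on the acrylamide chain

The compounds below may be only part of what the source reports. "The series", "measured", "known", "first", "only" and "open" are said of these compounds alone.

Compound 3 `COc1ccc(OC)c(/C=C/C(=O)Nc2cc3c(Nc4ccc(F)c(Cl)c4)ncnc3cc2O[C@H]2CCOC2)c1` stands lowest of the three numbers in a functional assay on PC-3 cells (Homo sapiens) for cytotoxicity, read by MTT assay, with a stated time of 72 h (on this read-out lower numbers stand for stronger inhibition and higher numbers for weaker inhibition), where compound 3 gives 8730 nM. Its nearest neighbour is compound 2 `COc1ccc(OC)c(/C=C/C(=O)Nc2cc3c(Nc4ccc(F)c(Cl)c4)ncnc3cc2OC)c1`, which gives 28600 nM, and furthest is compound 1 `COc1cc2ncnc(Nc3ccc(F)c(Cl)c3)c2cc1NC(=O)/C=C/c1ccc(F)cc1Cl`, which gives 32700 nM. Both gaps lie beyond the scatter: the step of a 3.3-fold lower number from compound 2 to compound 3 (0.52 log units; beyond the scatter) is modest, while the step of a 1.1-fold lower number from compound 1 to compound 2 (0.06 log units; within the scatter) is within the scatter.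

Compound 4 `O=C(/C=C/c1ccc(Br)cc1)Nc1cc2c(Nc3ccc(F)c(Cl)c3)ncnc2cc1O[C@H]1CCOC1` differs from compound 3 in one place: 4-bromophenyl in place of 2,5-dimethoxyphenyl on a double-bonded chain carbon bound to a double-bonded chain carbon. For the measured compounds named here, the only measured step that bears on this position is a 1.1-fold lower number from compound 1 to compound 2 (0.06 log units; within the scatter), where 2-chloro-4-fluorophenyl was replaced by 2,5-dimethoxyphenyl on the same double-bonded chain carbon and the number barely moved. Compound 4 reverses that kind of exchange, bringing 4-bromophenyl in where 2,5-dimethoxyphenyl stood, while keeping the oxolan-3-yl ether that distinguishes compound 3. Going by the values given here, since the one comparable change was within the scatter, the step of a 1.1-fold higher number from compound 3 to compound 4 (0.06 log units; within the scatter) is expected to be small, with no clear direction beyond the scatter. Compound 4 is therefore estimated at 10000 nM in this assay, within a range from 4000 nM to 25000 nM.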

Compound 4, half-maximal inhibitory concentration: 28200 nM
Beside the measured number, compound 4's estimate is 2.8-fold (0.45 log units) below it, outside the stated range (above it).
By their numbers in this assay, from the lowest: compound 3; then compounds 4, 2 and 1 (each within the scatter of the next).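

In this assay, for the compounds shown here, the aryl group on the double-bonded chain carbon proves able to move the number beyond the scatter, with a 3.2-fold higher number from compound 3 to compound 4 (0.51 log units; beyond the scatter), something the only earlier exchange at this position, a 1.1-fold lower number from compound 1 to compound 2 (0.06 log units; within the scatter), did not show. The low number of compound 3 therefore does not rest on the oxolan-3-yl ether alone, whose step a 3.3-fold lower number from compound 2 to compound 3 (0.52 log units; beyond the scatter) was read only with 2,5-dimethoxyphenyl on the chain: with the ether kept, 4-bromophenyl in place of 2,5-dimethoxyphenyl gives up a gain of about that size. Nothing available gives a reason for this step.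

The exchange removes two methoxy groups and brings in a bromine in one move, so the compounds shown do not tell whether the step follows the loss of the methoxy groups, the arrival of the bromine, or both together. Also open, as far as these compounds go, is how this position would read with an amine or a carboxylic acid on the phenyl ring, or with a longer chain between that ring and the amide carbonyl.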